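The source may hold more compounds than are shown below. What is called first, only, known or untested is meant among the compounds shown, and "the series" means these compounds.

Working notes on the series. Compound 1 `O=C1/C(=C/c2ccccc2Cl)CCc2c(O)cccc21` and compound 2 `O=C1/C(=C/c2ccccc2Br)CCc2c(O)cccc21` share one core and differ only in the halogen on the pendant ring. In a functional assay on RAW264.7 cells (Mus musculus) for inhibition (on this read-out higher numbers stand for weaker inhibition and lower numbers for stronger inhibition), compound 1 gives 1280 nM and compound 2 gives 1240 nM. The change that separates them is bromo in place of chloro on an aromatic carbon, and it made a 1.0-fold lower number from compound 1 to compound 2 (0.01 log units; within the scatter). Compound 3 `O=C1/C(=C/c2ccccc2Cl)CCc2cc(O)ccc21` carries the chloro group on a second core; the difference between the two cores is not broken down here. In this assay compound 3 gives 1910 nM, a number that lies within the scatter of both compound 1 and compound 2, so no order among the three is claimed.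

Compound 4 `O=C1/C(=C/c2ccccc2Br)CCc2cc(O)ccc21` has not yet been measured in this assay. It stands to compound 3 as compound 2 stands to compound 1: the change is bromo in place of chloro on an aromatic carbon, at a place described in the same words, so it is the same change. The step from compound 3 to compound 4 is expected to be about a 1.0-fold lower number from compound 3 to compound 4 (0.01 log units; within the scatter), essentially flat, because the matching step gave a 1.0-fold lower number from compound 1 to compound 2 (0.01 log units; within the scatter). Compound 4 is therefore estimated at 1850 nM in this assay, with a likely range from 1100 nM to 3200 nM.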

Compound 4, half-maximal inhibitory concentration: 1070 nM
Compound 4: the middle estimate sits 1.7-fold (0.24 log units) above what was measured; measured number outside the range, below it.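

In this assay the exchange of chloro for bromo on an aromatic carbon gives a 1.8-fold lower number from compound 3 to compound 4 (0.25 log units; within the scatter) on the core of compound 3, and set beside the same exchange on the core of compound 1 the picture is this: the same change on two cores in this assay, a 1.0-fold lower number (0.01 log units; within the scatter) from compound 1 to compound 2 and a 1.8-fold lower number (0.25 log units; within the scatter) from compound 3 to compound 4, 1.7-fold (0.24 log units) apart, within the scatter of two such steps

The change thus carries from the core of compound 1 to the core of compound 3 with no gap that can be told from the scatter, and neither step by itself lies beyond the scatter. This does not show that bromo and chloro differ on either core, nor that the two cores respond differently to the change, and two pairs give no rule for any further core.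

The compounds shown leave open whether fluoro, methyl, methoxy or nitrile in place of the halogen would give a step beyond the scatter on either core. They also leave open whether an amine or a carboxylic acid in place of the hydroxyl would give steps that carry between the two cores.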